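Replacing a ring in a compound at the assay limit

The source may hold more compounds than are shown below. What is called first, only, known or untested is meant among the compounds shown, and "the series" means these compounds.

In an ADME assay on HL-60 cells (Homo sapiens) for cytotoxicity, read by MTT assay, with a stated time of 24 h (on this read-out higher numbers stand for weaker inhibition and lower numbers for stronger inhibition), compound 2 `CN1CCC=C(c2ccc(CN(C)Cc3ccc(Cl)cc3)cc2)C1` gives > 50000 nM, which is a limit and not a number. Compound 1 `CC(C)CN(C)Cc1ccc(C2=CCCN(C)C2)cc1` gives > 50000 nM, also a limit. Compound 3 `CN1CCC=C(c2ccc(CN(C)CCCc3ccccc3)cc2)C1` gives > 50000 nM, again a limit. The three readings therefore share one mark: the limit of > 50000 nM in this assay, at which 3 of the 3 values shown sit.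

Compound 4 `CN(Cc1ccc(Cl)cc1)Cc1ccc(-c2cccnc2)cc1` keeps the 4-chlorophenyl of compound 2 and differs elsewhere: a group of 6 heavy atoms (5 carbon, 1 nitrogen; one six-membered aromatic ring with 1 hetero atom) in place of a group of 7 heavy atoms (6 carbon, 1 nitrogen; one six-membered non-aromatic ring with 1 hetero atom), on an aromatic carbon. Pyridin-3-yl thus enters on an aromatic carbon, whereas the measured steps all fall on a saturated chain carbon bound to an amine nitrogen. Those steps give no size: a step that the two limits leave unreadable from compound 1 to compound 2, a step that the two limits leave unreadable from compound 1 to compound 3 and a step that the two limits leave unreadable from compound 2 to compound 3.

None of them offers a size or direction to carry over, so the expectation rests on the shared limit alone, and no change beyond the scatter is anticipated in this assay. The estimate is a number no higher from compound 2 to compound 4 (the limit leaves the size open). Compound 4 is expected to read about 50000 nM, with an estimated range from 15000 nM to 100000 nM.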

Compound 4, half-maximal inhibitory concentration: 21000 nM
Estimate against measurement, compound 4: 2.4-fold (0.38 log units) above; the range from low to high includes it.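

In this assay, going by these compounds alone, the position on the aromatic carbon, para to a large group, is the first to give a readable change: pyridin-3-yl in place of the six-membered non-aromatic ring gives an at least 2.3-fold lower number from compound 2 to compound 4 (0.37 log units; beyond the scatter). Going by these compounds, the steps on the saturated chain carbon cannot be read, and the full size of this new step stays open, with only a limit for compound 2. Compound 4 is the only one of the four compounds with a reading that is a number, and the others remain at: the limit of > 50000 nM in this assay, at which 3 of the 4 values shown sit.

The compounds shown do not tell whether a phenyl or a pyridin-4-yl at this position would read like pyridin-3-yl. They also leave open whether pyridin-3-yl would have the same effect alongside the isopropyl of compound 1 or the phenethyl of compound 3.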